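This account rests on a few compounds, and the source may have more. Where it says the series, first, only, none or still open, it means among the compounds named here.

Compound 1, `COc1ccc(-c2nnc(N3CCN(C(=O)CN4CCN(c5ccccc5)CC4)CC3)nc2-c2ccc(OC)cc2)cc1`: in a functional assay on MCF7 cells (Homo sapiens) for cytotoxicity, read by MTT assay, with a stated time of 24 h (a lower number here means a stronger inhibitor, a higher number a weaker inhibitor), compound 1 gives > 863000 nM, which is a limit of the assay.
Compound 2, `COc1ccc(-c2nnc(N3CCN(C(=O)CN4CCN(c5ccccc5OC)CC4)CC3)nc2-c2ccc(OC)cc2)cc1`: in this assay compound 2 gives > 821000 nM, also a limit.
Compound 3, `COc1ccc(-c2nnc(N3CCN(C(=O)CN4CCN(c5ccc(OC)cc5)CC4)CC3)nc2-c2ccc(OC)cc2)cc1`: in this assay compound 3 gives > 821000 nM, again a limit.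

So compound 3 stands at the same limit as compound 2 (the limit of > 821000 nM in this assay, at which 2 of the 3 values shown sit), while compound 1 sits at a nearby limit (the limit of > 863000 nM in this assay, at which 1 of the 3 values shown sits). None of the three gave a number, so the steps between them (a step that the two limits leave unreadable from compound 1 to compound 2, a step that the two limits leave unreadable from compound 1 to compound 3, a step that the two limits leave unreadable from compound 2 to compound 3) cannot be read in size. Compound 4, `COc1ccc(-c2nnc(N3CCN(C(=O)CN4CCN(c5ccc(Cl)cc5)CC4)CC3)nc2-c2ccc(OC)cc2)cc1`, differs from compound 3 by chloro in place of methoxy on an aromatic carbon. No measured step bears on this change, and the shared core has shown no cytotoxicity here. Compound 4 is therefore expected to sit at about the same limit, an expected step of an at least 1.0-fold lower number from compound 3 to compound 4 (0.01 log units; that floor lies within the scatter). The estimate for compound 4 is 800000 nM, within 200000 nM to 2000000 nM.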

Compound 4, half-maximal inhibitory concentration: 607000 nM
Compound 4: middle estimate off by 1.3-fold (0.12 log units), on the high side; the range from low to high includes it.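

Among the four compounds, only compound 4 gives a number rather than a limit in this assay, so chloro on this aromatic carbon, para to a large group, gives the first readable value. Going by these compounds, its steps are an at least 1.3-fold lower number from compound 3 to compound 4 (0.13 log units; that floor lies within the scatter), an at least 1.3-fold lower number from compound 2 to compound 4 (0.13 log units; that floor lies within the scatter) and an at least 1.4-fold lower number from compound 1 to compound 4 (0.15 log units; that floor lies within the scatter), so each is only a floor and the true sizes stay unknown. Compound 3 remains a limit of the assay: the limit of > 821000 nM in this assay, at which 2 of the 4 values shown sit.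

On these data alone, whether fluoro, bromo or an amine at this place would also give a number stays open. So does whether chloro elsewhere on this ring would.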